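Free acid in place of ethyl ester on compound 1

The compounds below may be only part of what the source reports. "The series", "measured", "known", "first", "only" and "open" are said of these compounds alone.

The shared core carries an ethenyl ester in compound 1 `CCOC(=O)/C=C/c1ccncc1-c1ccc2[nH]ccc2c1` and compound 2 `CCOC(=O)/C=C/c1ccncc1-c1ccc2c(ccn2C)c1`, which differ only at an aromatic nitrogen, while compound 3 `O=C(O)[C@@H]1CCCN1C(=O)/C=C/c1ccncc1-c1ccc2ccccc2c1` carries an amide instead. In a functional assay on HCT-116 cells (Homo sapiens) for inhibition, read by MTT assay, with a stated time of 72 h (on this read-out higher numbers stand for weaker inhibition of growth and lower numbers for stronger inhibition of growth), compound 1 gives 4830 nM, the highest of the two numbers at hand, and compound 2 gives 210 nM; for compound 3 the result is "not determined" (no result reported). Within the data shown here, the only measured step, a 23-fold lower number from compound 1 to compound 2 (1.36 log units; beyond the scatter), concerns the aromatic nitrogen and not the ester. Compound 4 `O=C(O)/C=C/c1ccncc1-c1ccc2[nH]ccc2c1` differs from compound 1 by hydrogen in place of ethyl on an oxygen next to a carbonyl group. Among the measured compounds shown here, no measured step bears on this change, so its direction is open and a step beyond the scatter either way cannot be excluded. Compound 4 is expected near 8000 nM with a range of 2500 nM to 25000 nM, an estimated 1.7-fold higher number from compound 1 to compound 4 (0.22 log units; within the scatter).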

Compound 4, concentration for 50% growth inhibition: > 30000 nM
Compound 4 ended at the assay's limit; the forecaster's own chance of this, stated with the estimate: 20%; middle value at least 3.7-fold (0.57 log units) from the limit.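

In this assay, among these compounds, this is the first measured step at the ester itself: hydrogen in place of ethyl on an oxygen next to a carbonyl group gives an at least 6.2-fold higher number from compound 1 to compound 4 (0.79 log units; beyond the scatter), so growth inhibition is sensitive to this change as well as to the aromatic nitrogen. For compound 4 the result is a limit and not a number: the limit of > 30000 nM in this assay, at which 1 of the 4 values shown sits.

From the compounds shown here alone, whether a longer chain on this oxygen would keep or improve on the ethyl ester remains open. Also open, going by these compounds, is whether the same change on compound 2 gives a step of similar size, and how an amide in this place compares with the ester on the same core.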